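Ring methyl step carried from one core to another

A few compounds are considered here, and "the series" means these few. Any claim that something is new, unique, unknown or untested is made for them only; others in the source may bear on it.

Compound 1 `CC(C)(C)c1ccc2[nH]c(N3CCN(c4ncccc4Cl)CC3)nc2c1` gives 136 nM in a functional assay on HEK293 cells for antagonist activity at transient receptor potential cation channel subfamily V member 1 (Homo sapiens), read by FLIPR; on this read-out higher numbers stand for weaker inhibition and lower numbers for stronger inhibition. Compound 2 `C[C@H]1CN(c2ncccc2Cl)CCN1c1nc2cc(C(C)(C)C)ccc2[nH]1` carries methyl in place of hydrogen on a saturated ring carbon and in this assay gives 948 nM, a step of a 7.0-fold higher number from compound 1 to compound 2 (0.84 log units; beyond the scatter). Compound 3 `CC(C)(C)c1ccc2oc(N3CCN(c4ncccc4Cl)CC3)nc2c1` has another core; the difference between the two cores is not broken down here. In this assay, going by the values given here, compound 3 gives 2140 nM, the highest of the three numbers so far. Compound 4 `C[C@@H]1CN(c2ncccc2Cl)CCN1c1nc2cc(C(C)(C)C)ccc2o1` is compound 3 with methyl in place of hydrogen on a saturated ring carbon, the same change as from compound 1 to compound 2, at a place described in identical words, and it is not yet measured in this assay. Among the compounds with values here, the expectation for compound 4 rests on the measured pair, because a 7.0-fold higher number from compound 1 to compound 2 (0.84 log units; beyond the scatter) is the only gauge of this change. The step expected for compound 4 is a 5.6-fold higher number from compound 3 to compound 4 (0.75 log units; beyond the scatter). Compound 4 is estimated at 12000 nM, in a range from 4000 nM to 40000 nM.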

Compound 4, half-maximal inhibitory concentration: 305 nM
Beside the measured number, compound 4's estimate is 39-fold (1.59 log units) above it, and the stated range ends above it.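

In this assay the methyl on the saturated ring carbon does not carry from one core to the other, and a 7.0-fold lower number from compound 3 to compound 4 (0.85 log units; beyond the scatter) runs against the earlier step: the same change on two cores in this assay, a 7.0-fold higher number (0.84 log units; beyond the scatter) from compound 1 to compound 2 and a 7.0-fold lower number (0.85 log units; beyond the scatter) from compound 3 to compound 4, 49-fold (1.69 log units) apart, beyond the scatter of two such steps On these two pairs, the step measured on one core is no usable gauge for the other. This does not show that the core alone sets the direction, since the structures draw the methyl-bearing carbon of compound 2 and compound 4 with opposite configuration, and the two influences cannot be separated here.

Open, from the compounds shown here alone, is how the mirror-image methyl compound behaves on each core. Also open, going by these compounds, is whether ethyl or hydroxymethyl at the same ring carbon follows either direction.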